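Propyl to Isopropyl on the Ester Oxygen: Compound 4

The compounds below may be only part of what the source reports. "The series", "measured", "known", "first", "only" and "open" are said of these compounds alone.

Of the compounds shown here, three built on one shared core have been measured in an assay on membranes from HEK293 cells for displacement of a labelled ligand from adenosine receptor A2b (Homo sapiens), read by scintillation counting, with a stated time of 30 min, tested at 1 uM; a higher number here means more inhibition at the concentration tested (going by the name of the read-out), a lower number less inhibition. Compound 1, `CCCOC(=O)C1=C(C)N(C)C(=O)NC1c1ccco1`, gives 23% in this assay. Compound 2, `COC(=O)C1=C(C)N(C)C(=O)NC1c1ccoc1`, gives 7%. Compound 3, `CCCOC(=O)C1=C(C)N(C)C(=O)NC1c1ccoc1`, gives 2%, the lowest of the three numbers, though its gap to compound 2 lies within the scatter. Within the data shown here, the one step that is beyond the scatter, a number 21 percentage points lower from compound 1 to compound 3 (beyond the scatter), goes with moving the furan from one attachment point to the other. The other measured step, a number 5 percentage points lower from compound 2 to compound 3 (within the scatter), alters only the chain on the oxygen next to the carbonyl group and stays within the scatter.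

Compound 4, `CC1=C(C(=O)OC(C)C)C(c2ccoc2)NC(=O)N1C`, differs from compound 3 by isopropyl in place of propyl on an oxygen next to a carbonyl group. The change touches the same place as the move from propoxy seen in the step of a number 5 percentage points lower from compound 2 to compound 3 (within the scatter), and that step gave no movement beyond the scatter. Among the measured compounds shown here, with only that one comparison as a guide, no shift beyond the scatter is expected here either, in either direction. Compound 4 is therefore estimated to give about 4% in this assay, with a likely range from -8% to 16%, which corresponds to an expected step of a number 2 percentage points higher from compound 3 to compound 4 (within the scatter).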

Compound 4, a percentage reported as inhibition, at one concentration (the size of the read-out at that concentration, not a potency): 37%
Beside the measured number, compound 4's estimate is 33 percentage points below it; the measured number lies above the stated range.
By their numbers in this assay, from the lowest: compounds 3 and 2 (each within the scatter of the next); then compound 1; then compound 4.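

In this assay, among these compounds, the chain on the oxygen next to a carbonyl group matters more than the earlier compounds suggested: the only step there had stayed within the scatter, a number 5 percentage points lower from compound 2 to compound 3 (within the scatter) on going from methyl to propyl, and gave no sign that this place could move the read-out. Isopropyl now shows otherwise, with a number 35 percentage points higher from compound 3 to compound 4 (beyond the scatter) for a change that keeps the same carbon count and only joins the atoms differently, so the way the chain is joined counts here and not just its size, and a number 30 percentage points higher from compound 2 to compound 4 (beyond the scatter) shows that isopropyl also stands clear of methyl on the furan-3-yl compounds. Nothing available explains why isopropyl and propyl part so widely.

Among the compounds shown here, it remains open whether isopropyl would bring a similar step with the furan-2-yl group of compound 1, which is the only furan-2-yl compound here and carries propyl. Also open, as far as these compounds go, is whether a tert-butyl or a cyclopentyl group at this oxygen would take the number higher still, and how any of these percentages at a single concentration would translate into a potency.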